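A few compounds are considered here, and "the series" means these few. Any claim that something is new, unique, unknown or untested is made for them only; others in the source may bear on it.

Measured in a functional assay on the whole organism (blood, strain Wistar-Okamoto) with Rattus norvegicus as the target, with a stated time of 5 days; on this read-out higher numbers stand for an effect only at larger amounts of compound and lower numbers for an effect already at smaller amounts:
compound 1 `CC(C)CC/N=C(\NC#N)Nc1cccnc1`: 20 mg/kg
compound 2 `CCC(C)/N=C(\NC#N)Nc1cccnc1`: 20 mg/kg

Compound 2 stands level with compound 1 at the digits shown, and compound 1 is its only measured neighbour; the single measured step, no change at the digits printed from compound 1 to compound 2 (within the scatter), lies within the scatter. Compound 3 `CCC(CC)/N=C(\NC#N)Nc1cccnc1` differs from compound 2 by methyl in place of hydrogen on a saturated chain carbon, two bonds along the chain from a double-bonded nitrogen. Among the measured compounds shown here, only the step from compound 1 to compound 2 bears on this change, and that step also swapped one saturated chain for another without moving the read-out beyond the scatter. The change leading to compound 3 is smaller still in what enters, so no step beyond the scatter is expected in this assay in either direction, which is to say the expected step is no change at the digits printed from compound 2 to compound 3 (within the scatter). Compound 3 is therefore estimated at 20 mg/kg in this assay, with a range from 10 mg/kg to 40 mg/kg.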

Compound 3, minimum effective dose: 20 mg/kg
Beside the measured number, compound 3's estimate shows no gap at the digits printed, and the stated range covers the measured number.
By their numbers in this assay, from the lowest: compounds 1, 2 and 3 (each within the scatter of the next).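

In this assay, methyl in place of hydrogen on a saturated chain carbon, two bonds along the chain from a double-bonded nitrogen, gives no change at the digits printed from compound 2 to compound 3 (within the scatter) and so turns sec-butyl into pentan-3-yl without a step beyond the scatter. Among the compounds shown here, the earlier pair had swapped one saturated chain for another, whereas this is the first single added carbon at this position, and pentan-3-yl in place of isopentyl likewise gives no change at the digits printed from compound 1 to compound 3 (within the scatter) in this assay. Nothing at hand bears on a reason for this flat result.

The compounds shown leave open whether a longer chain on this nitrogen, or a chain ending in an amine or a carboxylic acid, would also stay within the scatter. They also say nothing about changes to the shared core, which is the same in all three.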